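The source may hold more compounds than are shown below. What is called first, only, known or untested is meant among the compounds shown, and "the series" means these compounds.

Series notes. Compound 1 `CCSc1n[nH]c(-n2[se]c3ccccc3c2=O)n1` gives 14100 nM in a functional assay on HeLa cells (Homo sapiens) for antiproliferative activity, read by CCK-8 assay, with a stated time of 48 h; on this read-out higher numbers stand for weaker inhibition and lower numbers for stronger inhibition. Compound 2 `CC(C)CSc1n[nH]c(-n2[se]c3ccccc3c2=O)n1` gives 34900 nM in this assay; the step of a 2.5-fold higher number from compound 1 to compound 2 (0.39 log units; beyond the scatter) lies beyond the scatter. Compound 3 `Cc1cccc(CSc2n[nH]c(-n3[se]c4ccccc4c3=O)n2)c1` gives 42600 nM in this assay: the step of a 3.0-fold higher number from compound 1 to compound 3 (0.48 log units; beyond the scatter) is beyond the scatter, whereas a 1.2-fold higher number from compound 2 to compound 3 (0.09 log units; within the scatter) is within it, so compound 3 and compound 2 cannot be told apart on this read-out. Compound 4 `CCCCCSc1n[nH]c(-n2[se]c3ccccc3c2=O)n1` carries butyl in place of 3-methylphenyl on a saturated chain carbon bound to a sulfur. Among the measured compounds shown here, the steps that bear on this are a 2.5-fold higher number from compound 1 to compound 2 (0.39 log units; beyond the scatter) and a 1.2-fold higher number from compound 2 to compound 3 (0.09 log units; within the scatter): growing the chain past methyl raised the number modestly, and swapping isopropyl for 3-methylphenyl gave nothing beyond the scatter. Compound 4, with its pentyl chain, is therefore expected to sit near compound 2 and compound 3, with the step of a 1.3-fold lower number from compound 3 to compound 4 (0.12 log units; within the scatter) expected to stay within the scatter. Compound 4 is estimated at 32000 nM, range 12000 nM to 85000 nM.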

Compound 4, half-maximal inhibitory concentration: 30300 nM
Compound 4: middle estimate off by 1.1-fold (0.02 log units), on the high side; the measured number falls inside the stated range.
By their numbers in this assay, from the lowest: compound 1; then compounds 4, 2 and 3 (each within the scatter of the next).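

At this position, on a saturated chain carbon bound to a sulfur, 3-methylbenzyl and pentyl cannot be told apart in this assay: the result is a 1.4-fold lower number from compound 3 to compound 4 (0.15 log units; within the scatter), so the aromatic ring is not required for this level. The pentyl chain also stays level with the group of compound 2, at a 1.2-fold lower number from compound 2 to compound 4 (0.06 log units; within the scatter), while a 2.1-fold higher number from compound 1 to compound 4 (0.33 log units; beyond the scatter) keeps compound 1 alone at the low end of these four. Nothing available explains this plateau. Going by these compounds, whether a longer chain, or a terminal amine or carboxylic acid, would move the number off this plateau remains open.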